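Capping a Chain Hydroxy Group: Expected Effect on Binding

The source may report more compounds than this note shows. Statements on the series, on what has been measured and on what is new or still open speak of the compounds shown alone.

Compound 1, `CCCn1c(=O)n(CCN(C)C)c(=O)c2[nH]cnc21`: 4300 nM
Compound 2, `CCCn1c(=O)n(CCCO)c(=O)c2[nH]cnc21`: 12000 nM

Two measured compounds share the same core and a propyl group and differ only at the far end of a three-carbon side chain. In an assay on Cerebral cortex for binding affinity to adenosine receptor A1 (Cavia porcellus), read by radioligand binding (on this read-out higher numbers stand for weaker inhibition and lower numbers for stronger inhibition), compound 1 gives 4300 nM and compound 2 gives 12000 nM. The step of a 2.8-fold higher number from compound 1 to compound 2 (0.45 log units; beyond the scatter) is modest yet beyond the scatter, so compound 2 holds the higher of the two numbers, that is, the weaker binding.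

Compound 3, `CCCn1c(=O)n(CCCOC)c(=O)c2[nH]cnc21`, arises from compound 2 by methyl in place of hydrogen on an oxygen on a saturated carbon. For the measured compounds named here, no measured pair shows this exact change. Going by the values given here, the one measured step, which swaps a dimethylamino for a hydroxymethyl, shows that reshaping the chain end moves the number only modestly, and the change here is smaller than that swap. A step within the scatter, in either direction, is therefore expected a 1.1-fold lower number from compound 2 to compound 3 (0.04 log units; within the scatter). Compound 3 is estimated at 11000 nM, with a range from 4000 nM to 30000 nM.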

Compound 3, inhibition constant: 12400 nM
Beside the measured number, compound 3's estimate is 1.1-fold (0.05 log units) below it; the range from low to high includes it.
By their numbers in this assay, from the lowest: compound 1; then compounds 2 and 3 (each within the scatter of the next).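

In this assay, going from hydroxy to methoxy gives a 1.0-fold higher number from compound 2 to compound 3 (0.01 log units; within the scatter) at the end of this chain, so methyl can take the place of the hydrogen on this oxygen with no shift that stands out from the usual scatter. The step of a 2.9-fold higher number from compound 1 to compound 3 (0.46 log units; beyond the scatter) is modest but beyond the scatter, so the dimethylamino compound stays apart from the methoxy compound as well as from the hydroxy compound. At this position, then, the hydrogen on the oxygen makes no readable difference, whereas the swap from dimethylamino does.

The compounds shown leave open what an ethoxy or benzyloxy group would do on this chain. They also leave open how a carboxylic acid at the chain end, or a longer chain, would read in this assay. No measured evidence here accounts for these results.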